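Fluoro removal on the fused ring of compound 1

This account rests on a few compounds, and the source may have more. Where it says the series, first, only, none or still open, it means among the compounds named here.

Measured compounds:
- compound 1 `CC[C@@H]1C(=O)N(C)c2cnc(-n3ccc4cc(F)ccc43)nc2N1C1CCCC1`: "not active" (no number reported)
- compound 2 `CC[C@@H]1C(=O)N(C)c2cnc(Nc3ccc(S(N)(=O)=O)cc3)nc2N1C1CCCC1`: 3390 nM
- compound 3 `CCC1C(=O)N(C)c2cnc(Nc3ccc(S(N)(=O)=O)cc3)nc2N1c1ccn(C)n1`: "not active" (no number reported)

In a functional assay on A549 cells (Homo sapiens) for antiproliferative activity, read by CCK-8 assay, with a stated time of 72 h (on this read-out higher numbers stand for weaker inhibition of growth and lower numbers for stronger inhibition of growth), compound 1 has no single number; compound 1 is recorded as "not active" (no number reported). Within the data shown here, compound 2 is the only member of this set with a value, and in this assay compound 2 gives 3390 nM. Compound 3 carries the same anilino sulfonamide as compound 2 but differs at the other nitrogen of the shared core; in this assay compound 3 is likewise recorded as "not active" (no number reported), so the set offers one number and two entries without one. Compound 4 `CC[C@@H]1C(=O)N(C)c2cnc(-n3ccc4ccccc43)nc2N1C1CCCC1` is the untested compound. It differs from compound 1 as follows: hydrogen in place of fluoro on an aromatic carbon. Among the measured compounds shown here, no step between measured compounds is available for this change; the hydrogen in place of fluoro on an aromatic carbon is expected to move compound 4 by no more than the scatter of this assay, in no clear direction, from an inactive starting point. Compound 4 is therefore expected to give 30000 nM, within a range of 5000 nM to 150000 nM, and most likely to return no number at all.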

Compound 4, concentration for 50% growth inhibition: 57500 nM
The estimate for compound 4 lay 1.9-fold (0.28 log units) below the measured number, and the stated range covers the measured number.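

No step can be read from compound 1 to compound 4, since compound 1 is recorded as "not active" (no number reported), whereas compound 4 gives 57500 nM in this assay. What the fluoro contributes to growth inhibition stays open, and nothing at hand offers a measured explanation.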